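Adding one carbon to the side chain of compound 3

The source may report more compounds than this note shows. Statements on the series, on what has been measured and on what is new or still open speak of the compounds shown alone.

- compound 1 `CC(=O)OCCC(=O)O[C@H](CC=C(C)C)C1=CC(=O)c2c(O)ccc(O)c2C1=O`: 15700 nM
- compound 2 `CCC(O)CO[C@H](CC=C(C)C)C1=CC(=O)c2c(O)ccc(O)c2C1=O`: 16400 nM
- compound 3 `CC[C@@](C)(O)CC(=O)O[C@H](CC=C(C)C)C1=CC(=O)c2c(O)ccc(O)c2C1=O`: 12700 nM
- compound 4 `CCCC(C)(O)CC(=O)O[C@H](CC=C(C)C)C1=CC(=O)c2c(O)ccc(O)c2C1=O`: not yet measured

All three numbers come from a functional assay on DU-145 cells (Homo sapiens) for cytotoxicity, read by MTT assay; on this read-out higher numbers stand for weaker inhibition and lower numbers for stronger inhibition. In this set compound 3, at 12700 nM, cannot be separated from its two neighbours, since its gaps to both lie within the usual scatter of repeated measurements.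

The next structure, compound 4, makes one small change: 1-hydroxy-1-methylbutyl in place of 1-hydroxy-1-methylpropyl on a saturated chain carbon bound to a carbonyl carbon. Read one bond further out, 2-hydroxy-2-methylbutyl becomes 2-hydroxy-2-methylpentyl.

For the measured compounds named here, no measured step is this exact change, but three steps among the measured compounds alter the same group on the shared core. They are a 1.0-fold higher number from compound 1 to compound 2 (0.02 log units; within the scatter), a 1.2-fold lower number from compound 1 to compound 3 (0.09 log units; within the scatter) and a 1.3-fold lower number from compound 2 to compound 3 (0.11 log units; within the scatter). Going by the values given here, each stays within the scatter, and these three compounds are the only evidence available. On that evidence, no step beyond the scatter is expected in this assay, in either direction. The expected step is a 1.0-fold lower number from compound 3 to compound 4 (0.01 log units; within the scatter). For compound 4 the estimated value is 12500 nM, with an expected range of 7000 nM to 22000 nM.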

Compound 4, half-maximal inhibitory concentration: 75000 nM
Compound 4: the middle estimate sits 6.0-fold (0.78 log units) below what was measured, outside the stated range (above it).
By their numbers in this assay, from the lowest: compounds 3, 1 and 2 (each within the scatter of the next); then compound 4.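

In this assay, for the compounds shown here, going from 1-hydroxy-1-methylpropyl to 1-hydroxy-1-methylbutyl gives a 5.9-fold higher number from compound 3 to compound 4 (0.77 log units; beyond the scatter), the first step in this set to lie beyond the scatter, so this saturated chain carbon bound to a carbonyl carbon is not as indifferent to its substituent as the earlier compounds suggested. The other two comparisons point the same way, with a 4.6-fold higher number from compound 2 to compound 4 (0.66 log units; beyond the scatter) and a 4.8-fold higher number from compound 1 to compound 4 (0.68 log units; beyond the scatter), which makes compound 4 the weakest of the four on this read-out, whereas the three earlier side chains could not be told apart. Nothing shown here bears on the reason for this loss of activity.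

The change also carries a second difference, since 1-hydroxy-1-methylpropyl has a defined stereocentre and 1-hydroxy-1-methylbutyl has none, so the effect of the longer chain cannot be separated from that of the undefined stereocentre. Going by these compounds, it also remains open whether a still longer chain such as 1-hydroxy-1-methylpentyl would weaken the number further, and whether an amine in place of the hydroxyl group would change the picture.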